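Removing the Bromo from Compound 2

The source may report more compounds than this note shows. Statements on the series, on what has been measured and on what is new or still open speak of the compounds shown alone.

Two thiosemicarbazone compounds have been examined in an ADME assay on MCF-10A cells (Homo sapiens) for cytotoxicity, read by sulforhodamine B assay, with a stated time of 48 h; on this read-out lower numbers stand for stronger inhibition of growth and higher numbers for weaker inhibition of growth. Compound 1 `NC(=S)N/N=C1/C(=O)N(CN2CCN(c3ccnc4cc(C(F)(F)F)ccc34)CC2)c2cccc(Br)c21` gives 30600 nM in this assay. Compound 2 `NC(=S)N/N=C1/C(=O)N(CN2CCN(c3ccnc4cc(C(F)(F)F)ccc34)CC2)c2cc(Br)ccc21`, which carries its bromo on a different aromatic carbon of the shared core, gives 27000 nM in this assay. These two values lie within the usual scatter of each other, so compound 2 stands alongside compound 1 rather than apart from it, and neither is set off by these numbers. Compound 3 `NC(=S)N/N=C1/C(=O)N(CN2CCN(c3ccnc4cc(C(F)(F)F)ccc34)CC2)c2ccccc21` has not yet been measured. It differs from compound 2 by hydrogen in place of bromo on an aromatic carbon. Shifting the bromo between compound 1 and compound 2 left the numbers within the scatter, and the data hold no step for removing it. The step of a 1.3-fold higher number from compound 2 to compound 3 (0.11 log units; within the scatter) is expected to be small, with no move beyond the scatter firmly expected in either direction. Compound 3 is accordingly estimated at 35000 nM, with a range from 15000 nM to 80000 nM.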

Compound 3, concentration for 50% growth inhibition: 22600 nM
Estimate against measurement, compound 3: 1.5-fold (0.19 log units) above; the measured number falls inside the stated range.
By their numbers in this assay, from the lowest: compounds 3, 2 and 1 (each within the scatter of the next).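

In this assay, hydrogen in place of bromo gives a 1.2-fold lower number from compound 2 to compound 3 (0.08 log units; within the scatter) and likewise gives a 1.4-fold lower number from compound 1 to compound 3 (0.13 log units; within the scatter). The earlier pair showed only that moving the bromo between two aromatic carbons of the shared core left the numbers within the scatter; compound 3 now shows that removing the bromo from either carbon also leaves them within the scatter, so none of the three compounds stands apart from the others. No accompanying measurement bears on this result.

The compounds shown span only bromo and hydrogen on these carbons, so it remains open whether an amine, a methoxy group or a carboxylic acid there would carry the number beyond the scatter. Also open, on these data alone, is whether changing the trifluoromethyl group elsewhere on the molecule would do so.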